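From 4-fluorophenyl to 2-nitrophenyl at an assay limit

The source may hold more compounds than are shown below. What is called first, only, known or untested is meant among the compounds shown, and "the series" means these compounds.

Measured in an ADME assay on HeLa cells (Homo sapiens) for cytotoxicity, read by MTT assay; on this read-out lower numbers stand for stronger inhibition and higher numbers for weaker inhibition:
- Compound 1 `N#Cc1c(-c2cccc(Cl)c2)c(C#N)c(=O)n(/N=C/c2cn(-c3ccccc3)nc2-c2ccccc2)c1N`: > 200 ug/mL
- Compound 2 `N#Cc1c(-c2ccc(Cl)cc2)c(C#N)c(=O)n(/N=C/c2cn(-c3ccccc3)nc2-c2ccccc2)c1N`: > 200 ug/mL
- Compound 3 `N#Cc1c(-c2ccc(F)cc2)c(C#N)c(=O)n(/N=C/c2cn(-c3ccccc3)nc2-c2ccccc2)c1N`: > 200 ug/mL

In this assay compound 3 gives > 200 ug/mL, which is a limit and not a number. The other two values are limits as well, so the series offers (the limit of > 200 ug/mL in this assay, at which 3 of the 3 values shown sit).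

Compound 4 `N#Cc1c(-c2ccccc2[N+](=O)[O-])c(C#N)c(=O)n(/N=C/c2cn(-c3ccccc3)nc2-c2ccccc2)c1N` has 2-nitrophenyl in place of 4-fluorophenyl on an aromatic carbon, opposite the ring nitrogen (2-nitrophenyl in place of 4-fluorophenyl on an aromatic carbon).

The measured changes closest to this one are a step that the two limits leave unreadable from compound 1 to compound 3 and a step that the two limits leave unreadable from compound 1 to compound 2. The remaining comparison is a step that the two limits leave unreadable from compound 2 to compound 3. For the measured compounds named here, none of the three has a size that can be carried over, and no measured compound carries 2-nitrophenyl. Going by the values given here, no step of readable size or direction is therefore expected in this assay, and another limit is the likeliest report.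

The expected move is a step that the limit leaves unreadable from compound 3 to compound 4. If a number is reported, the estimate for compound 4 is 220 ug/mL, within an expected range of 90 ug/mL to 400 ug/mL.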

Compound 4, half-maximal inhibitory concentration: > 200 ug/mL
Compound 4: a limit, no number; the forecaster's own chance of this, stated with the estimate: 75%; the middle value does not contradict the limit.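

In this assay, for the compounds shown here, compound 4 gives > 200 ug/mL, a limit and not a number, so no step between it and compound 1, compound 2 or compound 3 can be read. The compounds shown leave open whether any group at this aromatic carbon would give a measurable value: the limit of > 200 ug/mL in this assay, at which 4 of the 4 values shown sit.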